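The source may report more compounds than this note shows. Statements on the series, on what has been measured and on what is new or still open speak of the compounds shown alone.

In a functional assay on PC-3 cells (Homo sapiens) for inhibition (on this read-out lower numbers stand for stronger inhibition and higher numbers for weaker inhibition), compound 3 `Cc1c(C(=O)N/N=C\c2cccc(O)c2)oc2cccc(O)c12` gives 17600 nM, the highest of the three numbers measured. Compound 1 `Cc1c(C(=O)N/N=C\c2ccccc2O)oc2cccc(O)c12` gives 8350 nM in this assay, and compound 2 `Cc1ccc(O)c(/C=N\NC(=O)c2oc3cccc(O)c3c2C)c1` gives 7350 nM. The two steps leading to compound 3 both raised the number: a 2.1-fold higher number from compound 1 to compound 3 (0.32 log units; beyond the scatter) and a 2.4-fold higher number from compound 2 to compound 3 (0.38 log units; beyond the scatter). Between the other two, a 1.1-fold lower number from compound 1 to compound 2 (0.06 log units; within the scatter).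

Compound 4 `Cc1c(C(=O)N/N=C\c2ccc(Br)cc2O)oc2cccc(O)c12` differs from compound 3 in one place: 4-bromo-2-hydroxyphenyl in place of 3-hydroxyphenyl on a carbon with a double bond to nitrogen. Part of this change runs the step from compound 1 to compound 3 backwards, returning to a 2-hydroxyphenyl pattern, which is expected to bring the number back down by roughly that step. Going by the values given here, the bromine has no measured counterpart here; the only added substituent measured, the methyl of compound 2, moved the number within the scatter, so no extra shift is assumed. Compound 4 is therefore expected to show a 2.3-fold lower number from compound 3 to compound 4 (0.37 log units; beyond the scatter), landing near compound 1. The estimate for compound 4 is 7500 nM, with a range from 3500 nM to 15000 nM.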

Compound 4, half-maximal inhibitory concentration: 2050 nM
Compound 4: the middle estimate sits 3.7-fold (0.56 log units) above what was measured; measured number outside the range, below it.
By their numbers in this assay, from the lowest: compound 4; then compounds 2 and 1 (each within the scatter of the next); then compound 3.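

Going by these compounds alone, at this place, on a carbon with a double bond to nitrogen, the hydroxyphenyl group turns out to be far more sensitive to an added substituent than the earlier compounds suggested: bromo in place of hydrogen gives (a 4.1-fold lower number from compound 1 to compound 4 (0.61 log units; beyond the scatter)) in this assay, while the methyl step gave only (a 1.1-fold lower number from compound 1 to compound 2 (0.06 log units; within the scatter)). The 4-bromo-2-hydroxyphenyl group also outdoes the 2-hydroxy-5-methylphenyl group (a 3.6-fold lower number from compound 2 to compound 4 (0.55 log units; beyond the scatter)), and replacing 3-hydroxyphenyl with it gives the largest step in this set (an 8.6-fold lower number from compound 3 to compound 4 (0.93 log units; beyond the scatter)). Nothing available here explains the size of the bromo step.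

From the compounds shown here alone, what chloro, methoxy or an amine would do in place of the bromo remains open. So does whether bromo would give a similar step on the 3-hydroxyphenyl group.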